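Working notes on compound 1 and the step to compound 4

A few compounds are considered here, and "the series" means these few. Any claim that something is new, unique, unknown or untested is made for them only; others in the source may bear on it.

Of the compounds shown here, three have been measured, all in a functional assay on B16 cells (Mus musculus) for cytotoxicity, read by MTT assay, with a stated time of 48 h; on this read-out higher numbers stand for weaker inhibition and lower numbers for stronger inhibition. Compound 1 `CCOC(=O)Cn1cc(-c2ccc(OC)c(OC)c2OC)nn1` reaches only the limit of the assay, > 100000 nM. Compound 3 `Cc1ccc(-c2cn(CCCO)nn2)cc1` likewise gives only a limit in this assay, > 100000 nM. Within the data shown here, compound 2 `COc1cccc(Cn2cc(-c3ccc(C)cc3)nn2)c1` gives 19500 nM in this assay, the one numbered value among the three. Compound 1 therefore stands at the limit, the point at which two of the three values sit (the limit of > 100000 nM in this assay, at which 2 of the 3 values shown sit).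

Compound 4 `COc1ccc(-c2cn(C[C@H]3COC(C)(C)O3)nn2)c(OC)c1OC` is not yet measured. It differs from compound 1 in one place: 2,2-dimethyl-1,3-dioxolan-4-yl in place of ethoxycarbonyl on a saturated chain carbon bound to an aromatic nitrogen. Among the measured compounds shown here, no step between two measured compounds exists, so the size of this change cannot be read from any comparison; both chain variants seen so far on the core of compound 1 sit at the limit. Because compound 1 sits at > 100000 nM, compound 4 is expected to remain weak, and the step of a number no higher from compound 1 to compound 4 (the limit leaves the size open) is expected to be none beyond the scatter. Compound 4 is estimated at 100000 nM, between 30000 nM and 300000 nM, with a strong chance that this assay again reports only a limit.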

Compound 4, half-maximal inhibitory concentration: > 100000 nM
Compound 4 ended at the assay's limit; the forecaster's own chance of this, stated with the estimate: 70%; the middle value lies on the limit itself.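

In this assay compound 4 gives > 100000 nM as a limit of the assay, not a number. Compound 1 and compound 4 therefore yield no readable step: the limit of > 100000 nM in this assay, at which 3 of the 4 values shown sit. The compounds shown leave open whether (2,2-dimethyl-1,3-dioxolan-4-yl)methyl and (ethoxycarbonyl)methyl differ at all on the shared core.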